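Replacing 2-fluorophenyl with 3-nitrophenyl: a cytotoxicity estimate

A few compounds are considered here, and "the series" means these few. Any claim that something is new, unique, unknown or untested is made for them only; others in the source may bear on it.

Of the compounds shown here, two have numbers so far in an ADME assay on L02 cells (Homo sapiens) for cytotoxicity, read by MTT assay, with a stated time of 24 h (on this read-out higher numbers stand for weaker inhibition and lower numbers for stronger inhibition), and they sit close together. Compound 1 (`O=C1/C(=C/c2cccc([N+](=O)[O-])c2)CN(S(=O)(=O)c2ccc(F)cc2)C/C1=C\c1cccc([N+](=O)[O-])c1`) gives 15500 nM and compound 2 (`COc1cc(/C=C2\CN(S(=O)(=O)c3ccc(F)cc3)C/C(=C\c3ccccc3F)C2=O)cc(OC)c1OC`) gives 17600 nM in this test, a gap within the usual scatter of repeated measurements, so compound 2 cannot be told apart from compound 1. Compound 3 (`COc1cc(/C=C2\CN(S(=O)(=O)c3ccc(F)cc3)C/C(=C\c3cccc([N+](=O)[O-])c3)C2=O)cc(OC)c1OC`) keeps most of compound 2 but has 3-nitrophenyl in place of 2-fluorophenyl on a double-bonded chain carbon bound to a double-bonded ring carbon. Compound 1 also carries 3-nitrophenyl and gives 15500 nM here, so no step beyond the scatter is expected in this assay and neither direction is favoured. The expected 1.1-fold lower number from compound 2 to compound 3 (0.04 log units; within the scatter) is therefore small. For compound 3 the estimated value is 16000 nM (8000 nM to 32000 nM).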

Compound 3, half-maximal inhibitory concentration: 18800 nM
Beside the measured number, compound 3's estimate is 1.2-fold (0.07 log units) below it; measured number inside the range.
By their numbers in this assay, from the lowest: compounds 1, 2 and 3 (each within the scatter of the next).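

In this assay the swap of 2-fluorophenyl for 3-nitrophenyl gives a 1.1-fold higher number from compound 2 to compound 3 (0.03 log units; within the scatter) and so does not separate the two compounds, even though it brings in a nitro group with its two hydrogen-bond acceptors. The other new comparison, 3,4,5-trimethoxyphenyl in place of 3-nitrophenyl on a double-bonded chain carbon bound to a double-bonded ring carbon, gives a 1.2-fold higher number from compound 1 to compound 3 (0.08 log units; within the scatter) and likewise separates nothing, so all three groups tried at this position give numbers that cannot be told apart. No measurement at hand offers a reason for this.

On these data alone, whether an amine, a carboxylic acid or a longer chain at this position would move the number beyond the scatter remains open. As far as these compounds go, what changes elsewhere on the shared core would do also stays open.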